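From dimethylamino to 4-methylpiperidin-1-yl in compound 4

The compounds below may be only part of what the source reports. "The series", "measured", "known", "first", "only" and "open" are said of these compounds alone.

Compound 1 `CN(C)Cc1ccc2nc(NC(=O)N/N=C/c3cn(Cc4ccc(C(C)(C)C)cc4)c4ccccc34)sc2c1`: 810 nM
Compound 2 `CN(C)Cc1ccc2nc(NC(=O)N/N=C/c3cn(Cc4ccc(Cl)cc4Cl)c4ccccc34)sc2c1`: 950 nM
Compound 3 `CN(C)Cc1ccc2nc(NC(=O)N/N=C/c3cn(Cc4ccc(Cl)c(Cl)c4)c4ccccc34)sc2c1`: 1360 nM

In a functional assay on NCI-H460 cells (Homo sapiens) for cytotoxicity, read by MTT assay, with a stated time of 72 h (on this read-out higher numbers stand for weaker inhibition and lower numbers for stronger inhibition), compound 1 gives 810 nM. This value lies within the usual scatter of those of compound 2 and compound 3, so compound 1 holds no separate place among the three.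

Compound 4 `CC1CCN(Cc2ccc3nc(NC(=O)N/N=C/c4cn(Cc5ccc(C(C)(C)C)cc5)c5ccccc45)sc3c2)CC1`, not yet measured, departs from compound 1 in one place: 4-methylpiperidin-1-yl in place of dimethylamino on a saturated chain carbon bound to an aromatic carbon. In words, this is 4-methylpiperidin-1-yl in place of dimethylamino on a saturated chain carbon bound to an aromatic carbon.

The measured steps all concern a different place, a saturated chain carbon bound to an aromatic nitrogen. They are a 1.2-fold higher number from compound 1 to compound 2 (0.07 log units; within the scatter), a 1.7-fold higher number from compound 1 to compound 3 (0.23 log units; within the scatter) and a 1.4-fold higher number from compound 2 to compound 3 (0.16 log units; within the scatter). All three stay within the scatter. Among the compounds with values here, no measured compound varies the dimethylamino group, so these steps bear on the new change only indirectly and give it no direction. No step beyond the scatter is therefore expected in this assay. The expected step is a 1.1-fold lower number from compound 1 to compound 4 (0.03 log units; within the scatter). From the compounds shown here alone, the change itself is untested here, so the range is kept wide. For compound 4 the estimate is 750 nM, with an expected range from 280 nM to 2000 nM.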

Compound 4, half-maximal inhibitory concentration: 3370 nM
The estimate for compound 4 lay 4.5-fold (0.65 log units) below the measured number; measured number above the stated range.
By their numbers in this assay, from the lowest: compounds 1, 2 and 3 (each within the scatter of the next); then compound 4.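

In this assay, this is the first change among the compounds shown that moves the number beyond the scatter: the swap of dimethylamino for 4-methylpiperidin-1-yl gives a 4.2-fold higher number from compound 1 to compound 4 (0.62 log units; beyond the scatter), toward weaker inhibition. The earlier steps shown here all lay on the saturated chain carbon bound to an aromatic nitrogen and all stayed within the scatter, so they gave no sign that the saturated chain carbon bound to an aromatic carbon would be the more sensitive place of the two. The computed counts of hydrogen-bond donors and acceptors and the net charge are the same for both groups, and the difference lies in the added heavy atoms and the six-membered non-aromatic ring, but nothing in the data shown accounts for the rise in the number.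

The compounds shown leave open whether the step comes from the ring itself, from the methyl group on it, or from the added carbons, which a plain piperidin-1-yl, a pyrrolidin-1-yl or a diethylamino group at this place would help to separate. They also leave open how a morpholin-4-yl group would read here, and whether 4-methylpiperidin-1-yl gives a similar step alongside the dichlorophenyl groups of compound 2 and compound 3.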